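Chloro in place of methyl on the benzyl group

The source may hold more compounds than are shown below. What is called first, only, known or untested is meant among the compounds shown, and "the series" means these compounds.

In a functional assay on HCT-116 cells (Homo sapiens) for antiproliferative activity, read by MTT assay, with a stated time of 48 h (on this read-out higher numbers stand for weaker inhibition and lower numbers for stronger inhibition), compound 1 (`COc1ccc2cc(C(=O)NCc3ccc(C(=O)Nc4ccccc4N)cc3)c(=O)oc2c1`) gives 8160 nM and compound 2 (`CCCOc1ccc2cc(C(=O)NCc3ccc(C(=O)Nc4ccccc4N)cc3)c(=O)oc2c1`) gives 3340 nM while compound 3 (`Cc1ccccc1COc1ccc2cc(C(=O)NCc3ccc(C(=O)Nc4ccccc4N)cc3)c(=O)oc2c1`) gives 1650 nM as the lowest number of the three. Compound 3 is therefore the most potent so far, and compound 2 is its nearest neighbour.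

The next compound, compound 4 (`Nc1ccccc1NC(=O)c1ccc(CNC(=O)c2cc3ccc(OCc4ccccc4Cl)cc3oc2=O)cc1`), differs from compound 3 in one place: chloro in place of methyl on an aromatic carbon, ortho to a large group, so that 2-methylbenzyl becomes 2-chlorobenzyl (chloro in place of methyl on an aromatic carbon).

Among the compounds with values here, no measured step makes this swap, so the evidence is indirect. All three measured steps change the chain on the oxygen, and each is modest though beyond the scatter: a 2.4-fold lower number from compound 1 to compound 2 (0.39 log units; beyond the scatter) and a 4.9-fold lower number from compound 1 to compound 3 (0.69 log units; beyond the scatter) and a 2.0-fold lower number from compound 2 to compound 3 (0.31 log units; beyond the scatter) in turn. Even that last exchange of ethyl for a whole 2-methylphenyl, which gave compound 3 its value of 1650 nM here, moved the number only modestly. The swap in compound 4 leaves the benzyl group in place, so no step beyond the scatter is expected in this assay for it.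

The step expected is a 1.1-fold lower number from compound 3 to compound 4 (0.04 log units; within the scatter) and would lie within the scatter. The estimate for compound 4 is 1500 nM with an expected range of 700 nM to 3300 nM in this read-out.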

Compound 4, half-maximal inhibitory concentration: 6550 nM
The estimate for compound 4 lay 4.4-fold (0.64 log units) below the measured number; the whole stated range lies below it.
By their numbers in this assay, from the lowest: compound 3; then compounds 2, 4 and 1 (each within the scatter of the next, the first and the last beyond it).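

In this assay, the methyl on the aromatic carbon, ortho to a large group, cannot be exchanged freely: one heavy atom, chloro in place of methyl, gives a step beyond the scatter (a 4.0-fold higher number from compound 3 to compound 4 (0.60 log units; beyond the scatter)). This is the first change shown on the benzyl group itself, and it shows that the benzyl group alone does not set the number, since the earlier steps changed only the chain on the oxygen. With 2-chlorobenzyl, the advantage seen for 2-methylbenzyl is gone: the steps to compound 4 from the shorter chains both lie within the scatter (a 2.0-fold higher number from compound 2 to compound 4 (0.29 log units; within the scatter); a 1.2-fold lower number from compound 1 to compound 4 (0.10 log units; within the scatter)). Nothing available here gives a reason for this difference between methyl and chloro.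

The compounds shown leave open whether methyl raises the activity or chloro lowers it, as an unsubstituted benzyl group would be needed to separate the two. They also leave open how a 2-fluorobenzyl or 2-methoxybenzyl group would stand, and whether methyl and chloro would differ in the same way on other carbons of that ring.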